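The compounds below may be only part of what the source reports. "The series", "measured", "known", "first", "only" and "open" are said of these compounds alone.

Measured compounds in a functional assay on Jurkat cells (Homo sapiens) for inhibition; a lower number here means a stronger inhibitor, a higher number a weaker inhibitor:
Compound 1 `CC(C)[C@H](NC(=O)COc1cccc2ccccc12)C(=O)N[C@@H](CC(=O)O)C(=O)COc1cc(C(F)(F)F)n(C)n1` gives 46000 nM.
Compound 2 `CC(C)[C@H](NC(=O)COc1cccc2ccccc12)C(=O)N[C@@H](CC(=O)O)C(=O)CSC1=NCCS1` gives only a limit, > 200000 nM.
Compound 3 `CC(C)[C@H](NC(=O)COc1cccc2ccccc12)C(=O)N[C@@H](CC(=O)O)C(=O)CSc1nc[nH]n1` gives only a limit, > 200000 nM.

Compound 3 therefore stands at the edge of what this assay reports; it shares that position with compound 2, as the limit of > 200000 nM in this assay, at which 2 of the 3 values shown sit, records, and no number separates the two. Compound 4 `CC(C)[C@H](NC(=O)COc1cccc2ccccc12)C(=O)N[C@@H](CC(=O)O)C(=O)CSc1nc2ccccc2s1` differs from compound 3 by 1,3-benzothiazol-2-yl in place of 1H-1,2,4-triazol-3-yl on a sulfur. Among the measured compounds shown here, the measured steps that touch this part of the core are an at least 4.3-fold higher number from compound 1 to compound 2 (0.63 log units; beyond the scatter) and an at least 4.3-fold higher number from compound 1 to compound 3 (0.63 log units; beyond the scatter), both running from the one numbered value to a limit, and a step that the two limits leave unreadable from compound 2 to compound 3, which the two limits leave without size. No measured step exchanges one sulfanyl-bound ring for another with a readable outcome, so the change from compound 3 to compound 4 has no direct precedent among these three compounds. The expectation for compound 4 is therefore a step of an at least 1.3-fold lower number from compound 3 to compound 4 (0.12 log units; that floor lies within the scatter) in this assay, with a real chance that only a limit is again reported. Compound 4 is estimated at 150000 nM, within 30000 nM to 300000 nM.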

Compound 4, half-maximal inhibitory concentration: > 200000 nM
Compound 4 ended at the assay's limit (the forecaster's own chance of this, stated with the estimate: 60%); at least 1.3-fold (0.12 log units) between middle value and limit.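

In this assay compound 4 gives > 200000 nM, which is a limit and not a number. Exchanging 1H-1,2,4-triazol-3-yl for 1,3-benzothiazol-2-yl on the sulfur, with more heavy atoms and no hydrogen-bond donor, therefore yields no readable value, and the steps among compound 2, compound 3 and compound 4 cannot be read. The one readable new step again starts from the oxygen-linked pyrazole, an at least 4.3-fold higher number from compound 1 to compound 4 (0.63 log units; beyond the scatter), and the limit now holds all the sulfur-linked compounds shown: the limit of > 200000 nM in this assay, at which 3 of the 4 values shown sit.

Going by these compounds, compound 1 differs from the others in both the linking atom and the ring, so the contribution of each remains open. A (1-methyl-5-(trifluoromethyl)-1H-pyrazol-3-yl)sulfanyl group or a (1,3-benzothiazol-2-yl)oxy group at this position would separate the two.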